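A few compounds are considered here, and "the series" means these few. Any claim that something is new, unique, unknown or untested is made for them only; others in the source may bear on it.

Read-out for the series: a functional assay on KB cells (Homo sapiens) for inhibition, read by MTT assay, with a stated time of 24 h, tested at 10 ug/mL; on this read-out lower numbers stand for less inhibition of growth and higher numbers for more inhibition of growth at the one concentration tested.

Compound 1 `O=C(O)CCCCC(CCSC(=O)c1ccccc1)SC(=O)c1ccccc1`: 2.68%
Compound 2 `O=C(CCCCC(CCSC(=O)c1ccccc1)SC(=O)c1ccccc1)Nc1ccccc1Cl`: 2.53%

For the measured compounds named here, compound 2 lies within the scatter of compound 1, the only other measured compound, so the two cannot be ranked. Both show little inhibition of growth at the one concentration tested.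

The next compound is compound 3 `O=C(CCCCC(CCSC(=O)c1ccccc1)SC(=O)c1ccccc1)Nc1cccc(Cl)c1`. The change is 3-chlorophenyl in place of 2-chlorophenyl on an amide-type nitrogen. It places 3-chlorophenyl in place of 2-chlorophenyl on an amide-type nitrogen, and the two compounds have the same atoms, joined differently.

Going by the values given here, only one measured step bears on this, and only loosely: a number 0.2 percentage points lower from compound 1 to compound 2 (within the scatter). That step put (2-chlorophenyl)amino in place of hydroxy on a carbonyl carbon. Among the compounds with values here, no measured pair compares 2-chlorophenyl with 3-chlorophenyl, so the data give no direct size for this change. No shift beyond the scatter is therefore expected in this assay, and no direction is favoured with any confidence. The expected step is a number 0.5 percentage points higher from compound 2 to compound 3 (within the scatter). Compound 3 is estimated at 3%, with an expected range of 0% to 12%.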

Compound 3, percent growth inhibition at one concentration: 16.6%
Compound 3: the middle estimate sits 13.6 percentage points below what was measured; the whole stated range lies below it.
By their numbers in this assay, from the lowest: compounds 2 and 1 (each within the scatter of the next); then compound 3.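

In this assay, moving between the two chlorophenyl groups on the amide-type nitrogen gives a number 14.1 percentage points higher from compound 2 to compound 3 (beyond the scatter), so with the same atoms joined differently, this position responds to the change. For the compounds shown here, replacing hydroxy on a carbonyl carbon now depends on the group that enters: (3-chlorophenyl)amino gives a number 13.9 percentage points higher from compound 1 to compound 3 (beyond the scatter), whereas (2-chlorophenyl)amino gave a number 0.2 percentage points lower from compound 1 to compound 2 (within the scatter), the only one of these steps that stays within the scatter. No supporting measurement explains the difference between the two chlorophenyl groups.

The compounds shown leave open whether the gain belongs to the 3-chlorophenyl group specifically, and an unsubstituted phenyl or a 3-bromophenyl group on the same amide-type nitrogen would test how far it extends. Also open, as far as these compounds go, is whether compound 3, at 16.6% in this assay at the one concentration tested, keeps its advantage when a longer chain stands between the carbonyl carbon and the rest of the shared core.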